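Replacing a serine side group with a gem-dimethyl pair

This account rests on a few compounds, and the source may have more. Where it says the series, first, only, none or still open, it means among the compounds named here.

Measured so far:
Compound 1, `CSC[C@H](NC(=O)c1ccc(C#Cc2ccccc2)cc1)C(=O)NO`, 2000 nM
Compound 2, `O=C(N[C@H](CO)C(=O)NO)c1ccc(C#Cc2ccccc2)cc1`, 36000 nM
Compound 3, `O=C(C[C@H](NC(=O)c1ccc(C#Cc2ccccc2)cc1)C(=O)NO)NCCCO`, 82000 nM

All three share one core and differ only in the group on the amide-type nitrogen. In a physicochemical assay for solubility (on this read-out lower numbers stand for lower solubility and higher numbers for higher solubility), compound 2 stands second highest of the three numbers: compound 3 sits above it, and compound 1 far below it, as the step of an 18-fold higher number from compound 1 to compound 2 (1.26 log units; beyond the scatter) shows. The other step, a 41-fold higher number from compound 1 to compound 3 (1.61 log units; beyond the scatter), also points upward from compound 1.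

Compound 4, `CC(C)(NC(=O)c1ccc(C#Cc2ccccc2)cc1)C(=O)NO`, has not yet been measured. It differs from compound 2 in one place: a group of 7 heavy atoms (4 carbon, 1 nitrogen, 2 oxygen; no ring) in place of a group of 7 heavy atoms (3 carbon, 1 nitrogen, 3 oxygen; no ring), on an amide-type nitrogen. The entering group has fewer oxygen atoms and fewer hydrogen-bond donors than the one it replaces, so the change runs back in the direction of compound 1 rather than toward compound 3. Both steps from compound 1 were large and upward; a step of the reverse kind is therefore expected here, smaller than either. Compound 4 is expected to give 8000 nM in this assay, within 2000 nM to 30000 nM, a step of a 4.5-fold lower number from compound 2 to compound 4 (0.65 log units; beyond the scatter).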

Compound 4, solubility: 182000 nM
Compound 4: middle estimate off by 23-fold (1.36 log units), on the low side; the measured number lies above the stated range.
By their numbers in this assay, from the lowest: compound 1; then compound 2; then compound 3; then compound 4.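

In this assay, a group on the amide-type nitrogen does not need more hydrogen-bond donors and acceptors to give a higher number: 1-(hydroxycarbamoyl)-1-methylethyl has fewer of both than the group it replaces, yet the result is a 5.1-fold higher number from compound 2 to compound 4 (0.70 log units; beyond the scatter) for this change. Against the sulfur-containing group, the same entering group gives a 91-fold higher number from compound 1 to compound 4 (1.96 log units; beyond the scatter), the largest step yet seen at this position. No measurement shown here explains either step.

The entering group also lacks the defined stereocentre of the group it replaces, so the compounds shown cannot separate the loss of that stereocentre from the change in atoms. On these data alone, whether a group carrying an amine or a carboxylic acid on the amide-type nitrogen would follow compound 4 also remains open.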